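A few compounds are considered here, and "the series" means these few. Any claim that something is new, unique, unknown or untested is made for them only; others in the source may bear on it.

In a functional assay on HeLa cells (Homo sapiens) for antiproliferative activity, read by MTT assay, with a stated time of 24 h (on this read-out higher numbers stand for weaker inhibition and lower numbers for stronger inhibition), compound 1 `Clc1ccccc1CSc1nnc(-c2ccc3c(c2)OCCO3)n1-c1ccccc1` gives 29000 nM and compound 2 `Clc1cccc(CSc2nnc(-c3ccc4c(c3)OCCO4)n2-c2ccccc2)c1` gives 15000 nM. These two values lie within the usual scatter of each other, so compound 2 stands level with compound 1 on the numbers available. Compound 3 `Brc1cccc(CSc2nnc(-c3ccc4c(c3)OCCO4)n2-c2ccccc2)c1` differs from compound 2 in one place: bromo in place of chloro on an aromatic carbon, with bromo in place of chloro on an aromatic carbon, meta to a large group. Within the data shown here, the only measured step nearby is a 1.9-fold lower number from compound 1 to compound 2 (0.29 log units; within the scatter), which stays within the scatter. That step swaps 2-chlorophenyl for 3-chlorophenyl and exchanges no halogen, so it bears on the new change only indirectly. No step beyond the scatter is therefore expected in this assay. The estimated step is no change at the digits printed from compound 2 to compound 3 (within the scatter). Compound 3 is expected at 15000 nM, with an estimated range of 7000 nM to 30000 nM.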

Compound 3, half-maximal inhibitory concentration: 44200 nM
The estimate for compound 3 lay 2.9-fold (0.47 log units) below the measured number; measured number outside the range, above it.
By their numbers in this assay, from the lowest: compounds 2, 1 and 3 (each within the scatter of the next, the first and the last beyond it).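

In this assay, among these compounds, the earlier compounds moved the chlorine around the ring without leaving the scatter, whereas exchanging the halogen on an aromatic carbon, meta to a large group, gives a 2.9-fold higher number from compound 2 to compound 3 (0.47 log units; beyond the scatter), a modest step and the first one here beyond the scatter. The 3-bromophenyl group does not separate in the same way from the 2-chlorophenyl group, with a 1.5-fold higher number from compound 1 to compound 3 (0.18 log units; within the scatter), so the step from chloro to bromo is seen only against the 3-chlorophenyl partner. Nothing available bears on the reason for the step from chloro to bromo.

The compounds shown leave open how fluoro, iodo, a methoxy group or an amine would read on this same aromatic carbon. They also leave open whether bromo in place of chloro gives a like step in the 2-chlorophenyl group of compound 1.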